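Swapping the furan for a trifluoromethylphenyl in compound 4

The compounds below may be only part of what the source reports. "The series", "measured", "known", "first", "only" and "open" are said of these compounds alone.

Compound 1 `O=C1NC(=O)/C(=C\c2ccc(OCC(=O)N3N=C(c4ccccc4)CC3c3ccc(C(F)(F)F)cc3)cc2)S1`: in an assay on cells for inhibition of histone deacetylase 8 (Homo sapiens), read by fluorescence, with a stated time of 30 min (on this read-out lower numbers stand for stronger inhibition and higher numbers for weaker inhibition), compound 1 gives 16000 nM.
Compound 2 `O=C1NC(=O)/C(=C\c2ccc(OCC(=O)N3N=C(c4ccc(F)cc4)CC3c3ccccc3Cl)cc2)S1`: in this assay compound 2 gives only a limit, > 50000 nM.
Compound 3 `O=C1NC(=O)/C(=C\c2ccc(OCC(=O)N3N=C(c4ccc(F)cc4)CC3c3ccco3)cc2)S1`: in this assay compound 3 gives only a limit, > 50000 nM.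

Compound 3 therefore stands at the limit of this assay, with no number of its own; compound 2 shares that position, as the limit of > 50000 nM in this assay, at which 2 of the 3 values shown sit, records. Going by the values given here, the single step among the measured compounds, a step that the two limits leave unreadable from compound 2 to compound 3, runs between two limits and gives no readable size.

Compound 4 `O=C1NC(=O)/C(=C\c2ccc(OCC(=O)N3N=C(c4ccc(F)cc4)CC3c3ccc(C(F)(F)F)cc3)cc2)S1` is reached from compound 3 by the change (4-(trifluoromethyl)phenyl in place of furan-2-yl on a saturated ring carbon). Among the compounds with values here, no measured step covers this change directly, so its size cannot be taken from the pairs already known. What the data do offer is compound 1, which carries the same 4-(trifluoromethyl)phenyl group on the saturated ring carbon and gives a number rather than a limit in this assay. A measurable value is therefore expected for compound 4, with the step of an at least 2.0-fold lower number from compound 3 to compound 4 (0.30 log units; that floor lies within the scatter), because compound 1 gives 16000 nM. The estimate for compound 4 in this assay is 25000 nM, in the range 10000 nM to 60000 nM, with a fair chance that only a limit is reported again.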

Compound 4, half-maximal inhibitory concentration: > 50000 nM
Compound 4: only a limit was reported; the forecaster's own chance of this, stated with the estimate: 40%; at least 2.0-fold (0.30 log units) between middle value and limit.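

Compound 4 shows that the 4-(trifluoromethyl)phenyl group on the saturated ring carbon does not by itself secure a readable number in this assay, since this compound again gives only a limit. Going by these compounds alone, the one readable step is an at least 3.1-fold higher number from compound 1 to compound 4 (0.49 log units; beyond the scatter), with fluoro in place of hydrogen on an aromatic carbon as the only change, so the group on the other side of the ring also counts for this read-out, and a change as small as this one is enough to reach the limit. The steps to compound 4 from compound 2 and from compound 3 cannot be read, and these three compounds share a single limit: the limit of > 50000 nM in this assay, at which 3 of the 4 values shown sit.

From the compounds shown here alone, the real size of the fluoro step stays open, as does whether it would hold with another group on the saturated ring carbon, given that only compound 1 carries a number. Also open, going by these compounds, is what a methoxy group, an amine or a carboxylic acid in place of the fluoro would give in this assay.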